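This account rests on a few compounds, and the source may have more. Where it says the series, first, only, none or still open, it means among the compounds named here.

Measured compounds:
Compound 1 `CS(=O)(=O)c1ccc2nc(-c3ccc(-c4cccc(F)c4)cc3)[nH]c2c1` gives 21 nM.
Compound 2 `CS(=O)(=O)c1ccc2nc(-c3ccc(-c4ccccc4O)cc3)[nH]c2c1` gives 336 nM.
Compound 3 `CS(=O)(=O)c1ccc2nc(-c3ccc(-c4ccncc4)cc3)[nH]c2c1` gives 2470 nM.

In an assay on isolated protein for inhibition of acyl-CoA desaturase 1 (Rattus norvegicus) (on this read-out lower numbers stand for stronger inhibition and higher numbers for weaker inhibition), compound 3 stands highest of the three numbers, with compound 2 nearest to it and compound 1 furthest away. Compound 4 `CS(=O)(=O)c1ccc2nc(-c3ccc(-c4ccsc4)cc3)[nH]c2c1` differs from compound 3 in one place: thiophen-3-yl in place of pyridin-4-yl on an aromatic carbon. Among the measured compounds shown here, no measured step exchanges one such ring for another, so the steps that bear on this change are those that removed the pyridin-4-yl ring, read backwards: a 7.4-fold higher number from compound 2 to compound 3 (0.87 log units; beyond the scatter) and a 120-fold higher number from compound 1 to compound 3 (2.07 log units; beyond the scatter). Both point the same way, toward a lower number once the pyridin-4-yl ring is gone, with the step involving compound 1 being the larger. Compound 4 is therefore expected to show a clearly lower number, a drop of about a 31-fold lower number from compound 3 to compound 4 (1.49 log units; beyond the scatter). For compound 4 the estimate is 80 nM, in a range from 20 nM to 400 nM.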

Compound 4, half-maximal inhibitory concentration: 104 nM
The estimate for compound 4 lay 1.3-fold (0.11 log units) below the measured number; the measured number falls inside the stated range.
By their numbers in this assay, from the lowest: compound 1; then compound 4; then compound 2; then compound 3.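

In this assay the position para to a large group turns out to accept a five-membered aromatic ring: thiophen-3-yl in place of pyridin-4-yl gives a 24-fold lower number from compound 3 to compound 4 (1.38 log units; beyond the scatter) in one step. So the weak result of compound 3 does not extend to every aromatic ring with one hetero atom. Thiophen-3-yl also compares well with 2-hydroxyphenyl, at a 3.2-fold lower number from compound 2 to compound 4 (0.51 log units; beyond the scatter) here, yet falls short of 3-fluorophenyl, with a 5.0-fold higher number from compound 1 to compound 4 (0.69 log units; beyond the scatter) as the step.

As far as these compounds go, whether ring size or the sulfur matters more stays open, and a furan-3-yl or plain phenyl ring would help separate the two. No measurement shown explains these differences.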